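Triazole series: methyl on the benzoate phenyl, cytotoxicity

A few compounds are considered here, and "the series" means these few. Any claim that something is new, unique, unknown or untested is made for them only; others in the source may bear on it.

Compound 2 `O=C(OCCCc1cn(-c2ccnc3cc(Cl)ccc23)nn1)c1ccccc1` carries a benzoate ester on a three-carbon chain from the triazole. Among the compounds with values here, in an ADME assay on HepG2 cells (Homo sapiens) for cytotoxicity, read by MTT assay, with a stated time of 24 h (on this read-out higher numbers stand for lower toxicity in this test and lower numbers for higher toxicity in this test), compound 2 gives 1200000 nM, the highest of the two numbers so far. The nearest is compound 1 `Clc1ccc2c(-n3cc(-c4ccccc4)nn3)ccnc2c1`, which in this assay gives 574000 nM, a lower number by a margin beyond the usual scatter; the two structures differ in more than one place, so only the two values themselves are compared here.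

Compound 3 `Cc1ccc(C(=O)OCCCc2cn(-c3ccnc4cc(Cl)ccc34)nn2)cc1` differs from compound 2 by methyl in place of hydrogen on an aromatic carbon, on an aromatic carbon of a six-membered aromatic ring of carbon only, para to a large group; read one bond further out, phenyl becomes 4-methylphenyl. Within the data shown here, no measured pair shows this change. The step of a 1.1-fold lower number from compound 2 to compound 3 (0.04 log units; within the scatter) is expected to stay within the usual scatter, with no clear direction. For compound 3 the estimate in this assay is 1100000 nM, within 500000 nM to 2500000 nM.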

Compound 3, half-maximal cytotoxic concentration: > 2460000 nM
Compound 3: only a limit was reported; the forecaster's own chance of this, stated with the estimate: 30%; middle value at least 2.2-fold (0.34 log units) from the limit.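

In this assay, within the data shown here, methyl on an aromatic carbon of a six-membered aromatic ring of carbon only, para to a large group, gives an at least 2.0-fold higher number from compound 2 to compound 3 (0.31 log units; beyond the scatter) and so provides the first single-place comparison. Phenyl to 4-methylphenyl therefore moves the number upward, towards lower toxicity in this test, and the move lies beyond the scatter. Only the minimum size of this step is known, because the reading for compound 3 is a limit and not a number: the limit of > 2460000 nM in this assay, at which 1 of the 3 values shown sits.

One methyl at one place is a single case, and compound 2 and compound 3 establish no trend on the benzoate phenyl. Going by these compounds, whether an amine or a carboxylic acid at this place, or a longer chain leading to the ester, would shift the number in the same direction remains open.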